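This account rests on a few compounds, and the source may have more. Where it says the series, first, only, none or still open, it means among the compounds named here.

Measured so far:
compound 1 `CNS(=O)(=O)NC[C@@H]1CCCc2cc(S(=O)(=O)c3cccc(F)c3)ccc21` gives 1 nM
compound 2 `O=S(=O)(c1cccc(F)c1)c1ccc2c(c1)CCC[C@H]2CN1CCCS1(=O)=O` gives 31.6 nM

Both numbers come from an assay on isolated protein for displacement of a labelled ligand from 5-hydroxytryptamine receptor 6 (Homo sapiens); on this read-out higher numbers stand for weaker inhibition and lower numbers for stronger inhibition. Among the compounds with values here, compound 2 stands at the higher of the two numbers; the single measured step, a 32-fold higher number from compound 1 to compound 2 (1.50 log units; beyond the scatter), is large. Compound 3 `O=C(NC[C@@H]1CCCc2cc(S(=O)(=O)c3cccc(F)c3)ccc21)c1ncc[nH]1` differs from compound 2 by a group of 8 heavy atoms (4 carbon, 3 nitrogen, 1 oxygen; one five-membered aromatic ring with 2 hetero atoms) in place of a group of 7 heavy atoms (3 carbon, 1 nitrogen, 2 oxygen, 1 sulfur; one five-membered non-aromatic ring with 2 hetero atoms), on a saturated chain carbon bound to a saturated ring carbon. The change sits at the same place as the earlier step, so a sizable move is plausible. Because the earlier step of a 32-fold higher number from compound 1 to compound 2 (1.50 log units; beyond the scatter) was large, a substantial step is expected here, toward a lower number: a 6.3-fold lower number from compound 2 to compound 3 (0.80 log units; beyond the scatter). Compound 3 is therefore estimated at 5 nM, within a range from 1 nM to 25 nM.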

Compound 3, inhibition constant: 15.9 nM
For compound 3 the middle estimate is 3.2-fold (0.50 log units) below the measured one, within the range that was stated.
By their numbers in this assay, from the lowest: compound 1; then compounds 3 and 2 (each within the scatter of the next).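

The step of a 2.0-fold lower number from compound 2 to compound 3 (0.30 log units; within the scatter) shows that swapping the closed five-membered sulfur-containing ring for ((1H-imidazol-2-yl)carbonyl)amino at this place leaves the number within the usual scatter. The step of a 16-fold higher number from compound 1 to compound 3 (1.20 log units; beyond the scatter) shows that a second, quite different group also falls well short of methylsulfamoyl, so among these three compounds only compound 1 reaches the lowest number. No measurement shown explains these differences. Going by these compounds, it remains open whether the low number needs the methylsulfamoyl group itself, or whether methanesulfonyl or acetyl on the same amine nitrogen would match it.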